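The source may hold more compounds than are shown below. What is called first, only, known or untested is meant among the compounds shown, and "the series" means these compounds.

Measured so far in a functional assay on KB 3-1 cells (Homo sapiens) for cytotoxicity, read by MTT assay, with a stated time of 72 h; on this read-out higher numbers stand for weaker inhibition and lower numbers for stronger inhibition:
- compound 1 `CN(C)c1ccc(NC(=S)N/N=C2\C(=O)Nc3ccccc32)cc1` gives 6950 nM
- compound 2 `O=C1Nc2ccccc2/C1=N/NC(=S)Nc1ccc(C(=O)O)cc1` gives > 50000 nM as a limit

Compound 2 gives only a limit and no number, and it stands at the limit of > 50000 nM in this assay, at which 1 of the 2 values shown sits, on the scale.

The next compound, compound 3 `CCc1ccc(NC(=S)N/N=C2\C(=O)Nc3ccccc32)cc1`, carries ethyl in place of carboxy on an aromatic carbon, para to a large group (ethyl in place of carboxy on an aromatic carbon).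

Going by the values given here, the one measured step that bears on this is an at least 7.1-fold higher number from compound 1 to compound 2 (0.85 log units; beyond the scatter) for carboxy in place of dimethylamino on an aromatic carbon. Compound 3 also has no carboxy, so a move back toward compound 1 is expected in this assay, to a lower number and beyond the scatter. Among the compounds with values here, compound 1 at 6950 nM is the only true number, and it anchors the expectation. The true size of that earlier step is open on one side, so the range stays wide.

The expected change is an at least 5.5-fold lower number from compound 2 to compound 3 (0.74 log units; beyond the scatter) as a drop beyond the scatter.

For compound 3 the estimated value is 9000 nM with 3000 nM to 30000 nM as the expected range.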

Compound 3, half-maximal inhibitory concentration: 4050 nM
For compound 3 the middle estimate is 2.2-fold (0.35 log units) above the measured one; the measured number falls inside the stated range.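

On these data alone, at this position, on an aromatic carbon para to a large group, the earlier pair could not show whether the weak result of carboxy depended on a return to dimethylamino specifically; in this assay, ethyl in place of carboxy gives an at least 12-fold lower number from compound 2 to compound 3 (1.09 log units; beyond the scatter), a large step whose true size stays open on one side. Compound 2 gives a limit and not a number: the limit of > 50000 nM in this assay, at which 1 of the 3 values shown sits. Ethyl in place of dimethylamino gives a 1.7-fold lower number from compound 1 to compound 3 (0.23 log units; within the scatter), so compound 1 and compound 3 cannot be told apart here, and a group of carbon only serves as well as dimethylamino at this place.

Only three groups at this one position are shown, and carboxy alone stands apart, so it stays open whether chloro, methoxy or a longer chain such as butyl would keep the number near those of compound 1 and compound 3 or move it. Also open, as far as these compounds go, is whether the higher number follows carboxy alone or would come with a methyl ester or a primary amide at the same place.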